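A few compounds are considered here, and "the series" means these few. Any claim that something is new, unique, unknown or untested is made for them only; others in the source may bear on it.

Measured so far in an ADME assay, in phosphate buffer, at 28 degrees C, at pH 7.0; on this read-out higher numbers stand for a longer-lived compound and lower numbers for a shorter-lived compound:
- compound 1 `CC(C)(C)C1=C(C(=O)O)N2C(=O)[C@H]([C@@H](O)c3ccccc3)[C@H]2O1`: 8.9 h
- compound 2 `CC(C)(C)C1=C(C(=O)O)N2C(=O)[C@H]([C@@H](O)CCc3ccccc3)[C@H]2O1`: 39 h

Within the data shown here, compound 2 stands highest of the two numbers; its nearest neighbour is compound 1, and the single step, a 4.4-fold higher number from compound 1 to compound 2 (0.64 log units; beyond the scatter), lies beyond the scatter. Compound 3 `CC(C)(C)C1=C(C(=O)O)N2C(=O)[C@H]([C@@H](O)CCc3ccncc3)[C@H]2O1` is the next compound, not yet measured. Its change from compound 2 is pyridin-4-yl in place of phenyl on a saturated chain carbon, three bonds along the chain from an oxygen on a saturated carbon and a saturated ring carbon. Among the measured compounds shown here, none of the measured steps bears on this change: the one step in hand alters the length of the chain and leaves the ring at its end unchanged, so it gives no guide to exchanging that ring. With nothing to argue for a shift in either direction, the step from compound 2 to compound 3 is expected to be a 1.1-fold lower number from compound 2 to compound 3 (0.05 log units; within the scatter), that is, none beyond the scatter. Compound 3 is therefore estimated at 35 h, with a range from 15 h to 80 h.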

Compound 3, half-life: 15.8 h
Compound 3: middle estimate off by 2.2-fold (0.35 log units), on the high side, within the range that was stated.
By their numbers in this assay, from the lowest: compounds 1 and 3 (each within the scatter of the next); then compound 2.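

In this assay, the ring at the end of the chain proves to matter as well as the chain length: with the chain held constant, pyridin-4-yl in place of phenyl gives a 2.5-fold lower number from compound 2 to compound 3 (0.39 log units; beyond the scatter) on this half-life read-out. Against compound 1, the 2-(pyridin-4-yl)ethyl group gives a 1.8-fold higher number from compound 1 to compound 3 (0.25 log units; within the scatter) and so does not hold a separation from the phenyl compound that exceeds the scatter, whereas the phenethyl compound 2 does. Nothing on hand accounts for the shift caused by this ring exchange.

Still open, from the compounds shown here alone, is whether the shift is particular to pyridin-4-yl or also appears with pyridin-3-yl, pyridin-2-yl or a fluorophenyl ring on the same chain. Also open, going by these compounds, is how a longer chain ending in pyridin-4-yl or phenyl would compare with compound 2 and compound 3.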